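The source may report more compounds than this note shows. Statements on the series, on what has been measured and on what is new or still open speak of the compounds shown alone.

Measured so far:
compound 1, `COc1ccc2c(c1)OC(COc1ccc(CCC(=O)O)c(F)c1)CC2`, 2110 nM in a functional assay on HEK293 cells for agonist activity at Free fatty acid receptor 1 (Homo sapiens), read by fluorescence and calcium flux, with a stated time of 10 min; a higher number here means that more compound is needed for the effect, a lower number that less compound is needed
compound 2, `CS(=O)(=O)CCCOc1ccc2c(c1)OC(COc1ccc(CCC(=O)O)c(F)c1)CC2`, 36300 nM in this assay

Compound 2 stands highest of the two numbers; its nearest neighbour is compound 1, and the step of a 17-fold higher number from compound 1 to compound 2 (1.24 log units; beyond the scatter) is beyond the scatter. Compound 3, `COCCOc1ccc2c(c1)OC(COc1ccc(CCC(=O)O)c(F)c1)CC2`, is not yet measured. It differs from compound 2 in one place: methoxy in place of (methylsulfonyl)methyl on a saturated chain carbon, two bonds along the chain from an oxygen on an aromatic ring. Among the compounds with values here, the only step that bears on this is a 17-fold higher number from compound 1 to compound 2 (1.24 log units; beyond the scatter), which was large. Compound 3 keeps a chain ether yet drops the sulfone, so a lower number than compound 2 is expected in this assay, short of compound 1. For compound 3 the expected step is a 6.1-fold lower number from compound 2 to compound 3 (0.78 log units; beyond the scatter). Compound 3 is estimated at 6000 nM, range 1800 nM to 20000 nM.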

Compound 3, half-maximal effective concentration: 2370 nM
Compound 3: middle estimate off by 2.5-fold (0.40 log units), on the high side; the range from low to high includes it.
By their numbers in this assay, from the lowest: compounds 1 and 3 (each within the scatter of the next); then compound 2.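

In this assay, the large step of a 15-fold lower number from compound 2 to compound 3 (1.19 log units; beyond the scatter) ties the high number of compound 2 to the 3-(methylsulfonyl)propoxy group, not to any chain at this place. Methoxymethyl in place of hydrogen on a saturated chain carbon bound to an oxygen on an aromatic ring gives a 1.1-fold higher number from compound 1 to compound 3 (0.05 log units; within the scatter), so this chain ether is tolerated. No data at hand account for the gap between the sulfone and ether chains. On these data alone, whether an amine, a carboxylic acid or a longer ether chain would be tolerated here remains open. Also open, as far as these compounds go, is whether a sulfone on a shorter chain behaves like 3-(methylsulfonyl)propoxy.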